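A few compounds are considered here, and "the series" means these few. Any claim that something is new, unique, unknown or untested is made for them only; others in the source may bear on it.

Measured in a functional assay on CCRF-CEM cells (Homo sapiens) for cytotoxicity, read by MTT assay, with a stated time of 72 h; a higher number here means a weaker inhibitor of growth, a lower number a stronger inhibitor of growth:
compound 1 `CCCOC(=O)Nc1ccc([Se]C#N)cc1` — 38400 nM
compound 2 `O=C(Nc1ccc([Se][Se]c2ccc(NC(=O)OCc3ccc([N+](=O)[O-])cc3)cc2)cc1)OCc1ccc([N+](=O)[O-])cc1` — 36500 nM
compound 3 `O=C(Nc1ccc([Se][Se]c2ccc(NC(=O)Oc3ccccc3)cc2)cc1)Oc1ccccc1` — 48100 nM

Compound 1 holds the second highest of the three numbers in this assay; compound 2 lies nearest to it and compound 3 furthest, and both gaps fall within the scatter, so no order among the three is claimed. Compound 4 `CC(C)COC(=O)Nc1ccc([Se]C#N)cc1` is not yet measured. It differs from compound 1 by methyl in place of hydrogen on a saturated chain carbon bound to two saturated chain carbons. Among the compounds with values here, no step between measured compounds is available, and none of the three measured compounds differ from another in one place, so the size of such a change has no precedent here. In this assay the step is expected to stay within the scatter, with at most a slight lean toward a lower number. Compound 4 is estimated at 34000 nM, with a range from 15000 nM to 80000 nM. This estimate corresponds to an expected step of a 1.1-fold lower number from compound 1 to compound 4 (0.05 log units; within the scatter).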

Compound 4, concentration for total growth inhibition: 38300 nM
Compound 4: the middle estimate sits 1.1-fold (0.05 log units) below what was measured, and the stated range covers the measured number.
By their numbers in this assay, from the lowest: compounds 2, 4, 1 and 3 (each within the scatter of the next).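

In this assay, within the data shown here, methyl in place of hydrogen on a saturated chain carbon bound to two saturated chain carbons, which turns propoxy into isobutoxy, gives the first one-place step (a 1.0-fold lower number from compound 1 to compound 4 (0.00 log units; within the scatter)). Among these compounds, this branching therefore stays within the scatter at this position, which the earlier compounds, none differing from another in one place, could not show. No evidence at hand accounts for the size of this step.

Going by these compounds, whether a longer chain or an amine in place of propoxy would also stay within the scatter remains open. This single step says nothing about changes elsewhere on the core of compound 1.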